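Aryl ether to aryl thioether on the shared core

A few compounds are considered here, and "the series" means these few. Any claim that something is new, unique, unknown or untested is made for them only; others in the source may bear on it.

Working notes on the shared core of compound 1 `Nc1cc(N)c2nc(-c3ccccc3)c(Oc3ccc(Cl)c(Cl)c3)nc2c1`. In a functional assay on LOX IMVI cells (Homo sapiens) for inhibition, read by sulforhodamine B assay, with a stated time of 48 h (on this read-out lower numbers stand for higher toxicity in this test and higher numbers for lower toxicity in this test), compound 1 gives 72400 nM, the highest of the two numbers available in this set. Compound 3 `CCOC(=O)[C@H](CCC(=O)O)NC(=O)c1ccc(Oc2nc3cc(N)cc(N)c3nc2-c2ccccc2)cc1` gives 57500 nM in this assay, which lies within the scatter of compound 1, so no order between these two is claimed. Compound 2 `CCOC(=O)[C@H](CCC(=O)O)NC(=O)c1ccc(CNc2nc3cc(N)cc(N)c3nc2-c2ccccc2)cc1` gives only a limit in this assay, < 100000 nM, and this is not a number; it is the limit of < 100000 nM in this assay, at which 1 of the 3 values shown sits.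

Compound 4 `Nc1cc(N)c2nc(-c3ccccc3)c(Sc3ccc(F)cc3)nc2c1` is not yet measured. It differs from compound 1 by (4-fluorophenyl)sulfanyl in place of 3,4-dichlorophenoxy on an aromatic carbon. Within the data shown here, no measured pair in this set covers such a change, so no measured step can be pointed to. The expectation for compound 4 in this assay is therefore a number within the scatter of compound 1, with no step beyond the scatter in either direction. Compound 4 is expected to give 70000 nM, with a range from 30000 nM to 160000 nM. This estimate means a step from compound 1 to compound 4 of a 1.0-fold lower number from compound 1 to compound 4 (0.01 log units; within the scatter), expected to stay within the scatter.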

Compound 4, concentration lethal to 50% of the cells: 74100 nM
The estimate for compound 4 lay 1.1-fold (0.02 log units) below the measured number, within the range that was stated.
By their numbers in this assay, from the lowest: compounds 3, 1 and 4 (each within the scatter of the next).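

In this assay, among these compounds, (4-fluorophenyl)sulfanyl in place of 3,4-dichlorophenoxy on an aromatic carbon gives a 1.0-fold higher number from compound 1 to compound 4 (0.01 log units; within the scatter), the first measured step at this position. This position therefore accepts a sulfur-linked aryl group with a single fluorine in place of an oxygen-linked aryl group with two chlorines, with no difference beyond the scatter on this read-out. No measured property available here bears on this step.

The linking atom and the ring substituents change together in this one step, so their separate contributions cannot be told apart, and a flat result could arise from either no effect or offsetting effects. As far as these compounds go, whether the position stays this flat with a group of another kind, such as a piperidine or a plain alkyl chain in place of the aryl group, remains open.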